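Swapping 1-benzofuran-2-yl for ethynyl on the shared core

The source may report more compounds than this note shows. Statements on the series, on what has been measured and on what is new or still open speak of the compounds shown alone.

Compound 1 `COc1nc(N)nc2c1c(-c1cccs1)cn2[C@@H]1O[C@H](CO)[C@@H](O)[C@H]1O` gives > 100000 nM as a limit
Compound 2 `COc1nc(N)nc2c1c(-c1ccccc1)cn2[C@@H]1O[C@H](CO)[C@@H](O)[C@H]1O` gives > 100000 nM as a limit
Compound 3 `COc1nc(N)nc2c1c(-c1cc3ccccc3o1)cn2[C@@H]1O[C@H](CO)[C@@H](O)[C@H]1O` gives 22700 nM as a measured number

These values come from an ADME assay on MRC5 cells (Homo sapiens), read by MTT assay, with a stated time of 72 h (a lower number here means a stronger inhibitor, a higher number a weaker inhibitor), and only compound 3 has a readable number. Compound 4 `C#Cc1cn([C@@H]2O[C@H](CO)[C@@H](O)[C@H]2O)c2nc(N)nc(OC)c12` carries ethynyl in place of 1-benzofuran-2-yl on an aromatic carbon. Among the compounds with values here, two measured steps bear on this change, and both bring in 1-benzofuran-2-yl: an at least 4.4-fold lower number from compound 1 to compound 3 (0.64 log units; beyond the scatter) and an at least 4.4-fold lower number from compound 2 to compound 3 (0.64 log units; beyond the scatter) (both lower the number). The step that the two limits leave unreadable from compound 1 to compound 2 adds little. Losing that group should therefore reverse the drop, giving a modest rise toward the limit. The expected change is a 2.4-fold higher number from compound 3 to compound 4 (0.38 log units; beyond the scatter) (an estimate). Compound 4 is estimated at 55000 nM (expected range 10000 nM to 100000 nM).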

Compound 4, half-maximal inhibitory concentration: > 100000 nM
Compound 4: no number, only a limit; the forecaster's own chance of this, stated with the estimate: 50%; middle value at least 1.8-fold (0.25 log units) from the limit.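

Replacing 1-benzofuran-2-yl with the much smaller ethynyl, which has no ring, gives an at least 4.4-fold higher number from compound 3 to compound 4 (0.64 log units; beyond the scatter). The steps between compound 4 and compounds 1 and 2 cannot be read, as both ends of each are limits. At this aromatic carbon, compound 3 alone now has a readable number, and the other compounds all sit at the same limit: the limit of > 100000 nM in this assay, at which 3 of the 4 values shown sit.

Still open, going by these compounds, is whether another two-ring group, such as naphthalen-2-yl, would also give a readable number in this assay. The same question holds for an amine or a carboxylic acid on this carbon.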